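The compounds below may be only part of what the source reports. "The series", "measured", "known", "first", "only" and "open" are said of these compounds alone.

Measured so far:
- compound 1 `COc1ccc(-c2cc(C(=O)Nc3nc4ccc(Cl)cc4s3)nc3cc(-c4ccccc4)nn23)cc1OC` — in a functional assay on MCF7 cells (Homo sapiens) for cytotoxicity, read by MTT assay, with a stated time of 48 h (a higher number here means a weaker inhibitor, a lower number a stronger inhibitor), compound 1 gives 6910 nM
- compound 2 `COc1cc(-c2cc(C(=O)Nc3nc4ccc(Cl)cc4s3)nc3cc(-c4ccccc4)nn23)cc(OC)c1OC` — in this assay compound 2 gives 30200 nM

Compound 1 holds the lower of the two numbers; the step of a 4.4-fold higher number from compound 1 to compound 2 (0.64 log units; beyond the scatter) separates it from compound 2. Compound 3 `COc1ccc2nc(NC(=O)c3cc(-c4ccc(OC)c(OC)c4)n4nc(-c5ccccc5)cc4n3)sc2c1` differs from compound 1 by methoxy in place of chloro on an aromatic carbon. Among the measured compounds shown here, no measured step touches this position; the one step measured sits on the other aryl ring, so it gives no direct guidance, only a sense that single substituent changes move the number modestly. Compound 3 is therefore expected to land near compound 1, with a small shift of uncertain direction, a 1.4-fold higher number from compound 1 to compound 3 (0.16 log units; within the scatter), estimated at 10000 nM within 3000 nM to 35000 nM.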

Compound 3, half-maximal inhibitory concentration: 18700 nM
The estimate for compound 3 lay 1.9-fold (0.27 log units) below the measured number; the measured number falls inside the stated range.
By their numbers in this assay, from the lowest: compound 1; then compounds 3 and 2 (each within the scatter of the next).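

In this assay, replacing 6-chloro-1,3-benzothiazol-2-yl with 6-methoxy-1,3-benzothiazol-2-yl gives a 2.7-fold higher number from compound 1 to compound 3 (0.43 log units; beyond the scatter), showing that this position, untouched by the earlier step, also responds to a single substituent change. Among the two groups seen here, chloro gives the lower number, and both single changes from compound 1 now raise it. No measurement bears on why methoxy gives the higher number here.

On these data alone, it remains open whether chloro itself matters or whether any other group could give a lower number than compound 1. Fluoro, nitrile or an amine at this position would help separate these possibilities.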